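Series notes: one repeated substitution, one unmeasured compound

The source may report more compounds than this note shows. Statements on the series, on what has been measured and on what is new or still open speak of the compounds shown alone.

Compound 1 `CC(O)(CSc1cccc(S(F)(F)(F)(F)F)c1)C(=O)Nc1ccc(S(F)(F)(F)(F)F)cc1` and compound 2 `CC(O)(CSc1cccc(C(F)(F)F)c1)C(=O)Nc1ccc(S(F)(F)(F)(F)F)cc1` share one core and differ by a group of 4 heavy atoms (1 carbon, 3 fluorine; no ring) in place of a group of 6 heavy atoms (5 fluorine, 1 sulfur; no ring), on an aromatic carbon. In a functional assay on VCaP cells (Homo sapiens) for antiproliferative activity, read by propidium iodide staining, with a stated time of 96 h (on this read-out lower numbers stand for stronger inhibition and higher numbers for weaker inhibition), compound 1 gives 28200 nM and compound 2 gives 18800 nM; this is a 1.5-fold lower number from compound 1 to compound 2 (0.18 log units; within the scatter). Compound 3 `CC(O)(COc1cccc(S(F)(F)(F)(F)F)c1)C(=O)Nc1ccc(S(F)(F)(F)(F)F)cc1` stands on a different core, and the difference between the two cores is not broken down here. In this assay, for the measured compounds named here, compound 3 gives 11400 nM, a number within the scatter of compound 2 but beyond it against compound 1; with only three numbers, no ordering among the cores is claimed.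

Compound 4 `CC(O)(COc1cccc(C(F)(F)F)c1)C(=O)Nc1ccc(S(F)(F)(F)(F)F)cc1` is not yet measured. It differs from compound 3 by a group of 4 heavy atoms (1 carbon, 3 fluorine; no ring) in place of a group of 6 heavy atoms (5 fluorine, 1 sulfur; no ring), on an aromatic carbon, the same change as that from compound 1 to compound 2, at the same place. Among the measured compounds this change occurs once only, so the expectation rests on that single step. Expected is a 1.4-fold lower number from compound 3 to compound 4 (0.15 log units; within the scatter), a size that rests on a 1.5-fold lower number from compound 1 to compound 2 (0.18 log units; within the scatter) alone and stays within the scatter. In this assay compound 4 is estimated at 8000 nM, with a range from 4000 nM to 18000 nM.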

Compound 4, half-maximal inhibitory concentration: 24700 nM
For compound 4 the middle estimate is 3.1-fold (0.49 log units) below the measured one; measured number outside the range, above it.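

In this assay the trifluoromethyl group in place of the group of 6 heavy atoms gives a 2.2-fold higher number from compound 3 to compound 4 (0.34 log units; beyond the scatter) on the core of compound 3, and this does not match the step on the core of compound 1: the same change on two cores in this assay, a 1.5-fold lower number (0.18 log units; within the scatter) from compound 1 to compound 2 and a 2.2-fold higher number (0.34 log units; beyond the scatter) from compound 3 to compound 4, 3.3-fold (0.51 log units) apart, beyond the scatter of two such steps.

The change therefore does not carry over between these two cores in this series, and a step read on one of them is no safe guide to the size of the step on the other. This does not show how the change behaves on any further core or why the two steps differ, since the comparison rests on a single pair of compounds for each core.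

Open, going by these compounds, is whether the gap between the two cores holds for other groups at the same place on the ring, such as a chlorine atom, a nitrile or a methyl group. Also open, on these data alone, is how an amine or a carboxylic acid at that place would read on either core.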